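The source may hold more compounds than are shown below. What is called first, only, known or untested is meant among the compounds shown, and "the series" means these compounds.

Compound 1, `CC(C)[C@@H]1CC[C@@H](C)C[C@@]12N(C)C(=O)[C@@H]1[C@H]3C(=O)N(C)C(=O)[C@H]3ON12`, was tested in a functional assay, with a stated time of 20 min, tested at 2 mg/mL (on this read-out higher numbers stand for a stronger effect at the one concentration tested and lower numbers for a weaker effect), where compound 1 gives 53.4%. Of the two numbers recorded this is the highest, yet compound 2, `CC(C)[C@@H]1CC[C@@H](C)C[C@@]12N(C)C(=O)[C@@H]1[C@H]3C(=O)N(c4ccc(Cl)cc4)C(=O)[C@H]3ON12`, which gives 48.2%, lies within the scatter of it, so the two results cannot be told apart. Among the measured compounds shown here, the one measured step, a number 5.2 percentage points lower from compound 1 to compound 2 (within the scatter), belongs to the exchange of methyl for 4-chlorophenyl on an amide-type nitrogen in a ring. Compound 3, `COc1ccc(N2C(=O)[C@H]3[C@H](ON4[C@@H]3C(=O)N(C)[C@@]43C[C@H](C)CC[C@H]3C(C)C)C2=O)cc1`, has not yet been measured. It differs from compound 1 by 4-methoxyphenyl in place of methyl on an amide-type nitrogen in a ring. For the measured compounds named here, only the step from compound 1 to compound 2 bears on this change: a 4-chlorophenyl entering at the same place left the read-out within the scatter. A similar outcome is therefore expected here, a step of a number 4.4 percentage points lower from compound 1 to compound 3 (within the scatter), not beyond the scatter. Compound 3 is accordingly estimated at 49%, with a range from 37% to 61%.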

Compound 3, a percentage reported as activity, at one concentration (the size of the read-out at that concentration, not a potency): 61.7%
Estimate against measurement, compound 3: 12.7 percentage points below; measured number outside the range, above it.
By their numbers in this assay, from the lowest: compounds 2, 1 and 3 (each within the scatter of the next, the first and the last beyond it).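

In this assay, the exchange of methyl for 4-methoxyphenyl on the amide-type nitrogen gave a number 8.3 percentage points higher from compound 1 to compound 3 (within the scatter), so like 4-chlorophenyl, this aryl group cannot be told apart from methyl at this position. What the new result adds is that the group carried on the aromatic ring can matter: methoxy in place of chloro on an aromatic carbon gave a number 13.5 percentage points higher from compound 2 to compound 3 (beyond the scatter), a modest step and the only one beyond the scatter among those involving a single change. Nothing available here accounts for this difference.

The compounds shown leave open how the read-out would respond to an amine or a carboxylic acid on that aromatic carbon, or to an unsubstituted phenyl or a benzyl group on the nitrogen. As each compound was read at a single concentration, they also leave potency open.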